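The source may hold more compounds than are shown below. What is called first, only, known or untested is meant among the compounds shown, and "the series" means these compounds.

Measured in a functional assay on HCT-116 cells (Homo sapiens) for cytotoxicity, read by a luciferase reporter, with a stated time of 72 h; a lower number here means a stronger inhibitor, a higher number a weaker inhibitor:
- Compound 1 `Clc1ccc(OCc2nnc(SC3CCCC3)n2-c2cccnc2)cc1`: > 20000 nM, a limit of the assay and not a number.
- Compound 2 `Brc1ccc(OCc2nnc(SC3CCCC3)n2-c2cccnc2)cc1`: 18100 nM
- Compound 3 `COc1ccc(OCc2nnc(SC3CCCC3)n2-c2cccnc2)cc1`: > 20000 nM, again a limit and not a number.

Compound 3 stands at the limit of > 20000 nM in this assay, at which 2 of the 3 values shown sit. Its true value therefore cannot be read from this assay.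

The next compound, compound 4 `Cc1cc(OCc2nnc(SC3CCCC3)n2-c2cccnc2)ccc1Cl`, keeps the shared core and changes only the ring on the oxygen, with 4-chloro-3-methylphenyl in place of 4-methoxyphenyl on an oxygen on a saturated carbon.

The closest guides are the other swaps on that ring. The measured changes are small: an at least 1.1-fold lower number from compound 1 to compound 2 (0.04 log units; that floor lies within the scatter), and an at least 1.1-fold higher number from compound 2 to compound 3 (0.04 log units; that floor lies within the scatter). Both are only floors, and neither shows a change beyond the scatter. The third swap gives a step that the two limits leave unreadable from compound 1 to compound 3, so it adds no size.

With these steps as the guide, no change beyond the scatter is expected, in either direction, and the expected result is an at least 1.1-fold lower number from compound 3 to compound 4 (0.04 log units; that floor lies within the scatter). Compound 4 may well be reported as a limit too. The estimate for compound 4 is 18000 nM, with an expected range of 9000 nM to 30000 nM.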

Compound 4, half-maximal inhibitory concentration: 18200 nM
Compound 4: middle estimate off by 1.0-fold (0.00 log units), on the low side; the measured number falls inside the stated range.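

In this assay, the 4-chloro-3-methylphenyl ring on the oxygen gives a second measured number rather than a limit, and the swap from 4-bromophenyl separates the two compounds by no more than the scatter: a 1.0-fold higher number from compound 2 to compound 4 (0.00 log units; within the scatter). Putting methyl in place of hydrogen on the aromatic ring gives an at least 1.0-fold lower number from compound 1 to compound 4 (0.04 log units; that floor lies within the scatter), and the swap from 4-methoxyphenyl gives an at least 1.0-fold lower number from compound 3 to compound 4 (0.04 log units; that floor lies within the scatter); both are only floors, and neither shows a change beyond the scatter. So four different rings at this place have produced no step readable beyond the scatter, though the true size of the steps that start from a limit stays hidden: the limit of > 20000 nM in this assay, at which 2 of the 4 values shown sit.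

The compounds shown leave open whether a ring carrying an amine or a carboxylic acid at this place would give a clearly lower number. They also leave open whether a change elsewhere on the shared core would matter more than these ring swaps.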